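The source may hold more compounds than are shown below. What is called first, only, known or untested is meant among the compounds shown, and "the series" means these compounds.

Measured so far in an ADME assay on Vero cells (Chlorocebus sabaeus) for cytotoxicity; on this read-out higher numbers stand for lower toxicity in this test and lower numbers for higher toxicity in this test:
- compound 1 `CC(=O)OC[C@H]1O[C@@H](n2cc(-c3cc(-c4ccc(C(C)(C)C)cc4)no3)c(=O)[nH]c2=O)C[C@@H]1OC(C)=O` gives 3000 nM
- compound 2 `CC(=O)OC[C@H]1O[C@@H](n2cc(-c3cc(-c4ccc(C(C)C)cc4)no3)c(=O)[nH]c2=O)C[C@@H]1OC(C)=O` gives 3000 nM

In this assay compound 2 stands at 3000 nM, level with compound 1 at the digits given. The next compound, compound 3 `CCCCc1ccc(-c2cc(-c3cn([C@H]4C[C@H](OC(C)=O)[C@@H](COC(C)=O)O4)c(=O)[nH]c3=O)on2)cc1`, differs from compound 2 in a single place: butyl in place of isopropyl on an aromatic carbon. In words, this is butyl in place of isopropyl on an aromatic carbon, and the same difference can be read as 4-isopropylphenyl to 4-butylphenyl. Going by the values given here, only one measured step bears on it, a change in the same group: no change at the digits printed from compound 1 to compound 2 (within the scatter). Among the compounds with values here, that single step is thin evidence, and no measured compound carries a butyl group. Even so, it gives no reason to expect a real shift. The expected step is no change at the digits printed from compound 2 to compound 3 (within the scatter), which means no change beyond the scatter. For compound 3 the estimated value is 3000 nM, with an expected range from 1400 nM to 6000 nM.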

Compound 3, half-maximal cytotoxic concentration: 3000 nM
Compound 3: middle estimate and measured number agree at the digits printed; low and high end bracket the measured number.
By their numbers in this assay, from the lowest: compounds 1, 2 and 3 (each within the scatter of the next).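

In this assay, moving to the straight butyl chain gives no change at the digits printed from compound 2 to compound 3 (within the scatter) and, measured against the bulkier branched group, no change at the digits printed from compound 1 to compound 3 (within the scatter) in the same comparison. Going by these compounds alone, until now only two branched groups had been compared at this place on the aromatic carbon, para to a large group, so the read-out had not been tested against an unbranched chain. It now fails to separate butyl from either isopropyl or tert-butyl, and no measurement shown here explains this flat result.

As far as these compounds go, all three groups contain carbon and hydrogen only, so it remains open whether an amine, a carboxylic acid or a chain longer than butyl, such as octyl, would shift the read-out. From the compounds shown here alone, it is also open whether this flat picture would hold if the rest of the shared core were changed.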